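The compounds below may be only part of what the source reports. "The series", "measured", "known", "first", "only" and "open" are said of these compounds alone.

Measured in an ADME assay on MT4 cells (Homo sapiens) for cytotoxicity, read by MTT assay, with a stated time of 96 h; a higher number here means that more compound is tolerated, a lower number that less compound is tolerated:
- Compound 1 `C/C(=N\NC(N)=S)c1ccc2[nH]c(-c3ccccc3)nc2c1`: >= 100000 nM, a limit of the assay and not a number.
- Compound 2 `CC(=O)c1ccc2c(c1)nc(-c1ccccc1)n2C1CCCCC1`: 37000 nM.
- Compound 3 `C/C(=N\NC(N)=S)c1ccc2c(c1)nc(-c1ccccc1)n2C1CCCCC1`: 20000 nM.

In this assay, compound 3 gives 20000 nM. Within the data shown here, the only other actual number belongs to compound 2, at 37000 nM, and the two lie within the scatter of each other.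

Compound 4 `COc1ccc(-c2nc3cc(/C(C)=N/NC(N)=S)ccc3n2C2CCCCC2)cc1` is reached from compound 3 by methoxy in place of hydrogen on an aromatic carbon. This is methoxy in place of hydrogen on an aromatic carbon, so that phenyl becomes 4-methoxyphenyl.

Two measured steps end at compound 3. With cyclohexyl in place of hydrogen on an aromatic nitrogen, the data show an at least 5.0-fold lower number from compound 1 to compound 3 (0.69 log units; beyond the scatter). Compound 1 sits at a limit there: the limit of >= 100000 nM in this assay, at which 1 of the 3 values shown sits. The other step is a 1.9-fold lower number from compound 2 to compound 3 (0.27 log units; within the scatter). Among the measured compounds shown here, neither step changes the phenyl, so no measured step shows what a methoxy does at this place.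

The expectation therefore stays close to compound 3 at 20000 nM, with no step beyond the scatter and no firm direction. The estimate means a 1.1-fold lower number from compound 3 to compound 4 (0.05 log units; within the scatter), an expected change that stays small. For compound 4 the estimated value is 18000 nM, with an expected range from 7000 nM to 50000 nM.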

Compound 4, half-maximal cytotoxic concentration: 39000 nM
Compound 4: middle estimate off by 2.2-fold (0.34 log units), on the low side; the range from low to high includes it.
By their numbers in this assay, from the lowest: compounds 3, 2 and 4 (each within the scatter of the next). At a limit, above all of these: compound 1.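

In this assay, among these compounds, this is the first measured step that touches the phenyl itself, and putting 4-methoxyphenyl in its place gives a 2.0-fold higher number from compound 3 to compound 4 (0.29 log units; within the scatter) on this reading, so compound 3 and compound 4 cannot be told apart. Among the compounds shown here, the methoxy therefore shows that this aromatic carbon, para to a large group, can carry a substituent with no difference in tolerated concentration that stands clear of the usual scatter, whereas the earlier steps concerned only the aromatic nitrogen and the other side of the shared core. The single measurement of compound 4 gives no firm direction for this change, and nothing shown accounts for how compound 3 and compound 4 read.

From the compounds shown here alone, whether a larger or different group at this place, such as a chlorine, an amine or a carboxylic acid, would move the number beyond the scatter remains open, as does the effect of a methoxy on the other carbons of this phenyl. Also open, going by these compounds, is whether the same methoxy would behave alike on the core that lacks the cyclohexyl, or alongside the acetyl group in place of the thiosemicarbazone side chain.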